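The compounds below may be only part of what the source reports. "The series", "measured", "known", "first", "only" and "open" are said of these compounds alone.

Three closely related compounds have been tested in a functional assay on PC-12 cells (Rattus norvegicus) for cytotoxicity, read by MTT assay, with stated times of 2 h and 24 h, tested at 5 uM; a lower number here means a weaker effect, a higher number a stronger effect of the compound at the concentration tested. Compound 1 `CC(C)c1ccc(-n2nc(-c3ccc(C(F)(F)F)cc3O)nc2-c2ccccc2O)cc1` gives 100%, compound 2 `Oc1cc(C(F)(F)F)ccc1-c1nc(-c2ccccc2O)n(-c2ccc(F)cc2)n1` gives 86.7%, and compound 3 `Oc1cc(C(F)(F)F)ccc1-c1nc(-c2ccccc2O)n(-c2ccc(C(F)(F)F)cc2)n1` gives 90.5%. Compound 2 thus stands lowest of the three numbers; its step of a number 3.8 percentage points higher from compound 2 to compound 3 (within the scatter) lies within the usual scatter, while the step of a number 13.3 percentage points lower from compound 1 to compound 2 (beyond the scatter) is the only one beyond it.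

Compound 4 `Oc1cc(C(F)(F)F)ccc1-c1nc(-c2ccccc2O)n(-c2ccccc2C(F)(F)F)n1` is not yet measured. It differs from compound 2 in one place: 2-(trifluoromethyl)phenyl in place of 4-fluorophenyl on an aromatic nitrogen.

The measured steps that come closest to this change are a number 3.8 percentage points higher from compound 2 to compound 3 (within the scatter), in which trifluoromethyl replaced fluoro without moving the number beyond the scatter, and a number 9.5 percentage points lower from compound 1 to compound 3 (within the scatter), also within the scatter. Only a number 13.3 percentage points lower from compound 1 to compound 2 (beyond the scatter) went beyond the scatter, and it ran from isopropyl to fluoro. Taken together, these steps give no reason to expect a change beyond the scatter in this assay in either direction, so the estimate for compound 4 is 90%, with a range from 78% to 100%, meaning an expected step of a number 3.3 percentage points higher from compound 2 to compound 4 (within the scatter).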

Compound 4, a percentage reported as activity, at one concentration (the size of the read-out at that concentration, not a potency): 80%
Compound 4: the middle estimate sits 10 percentage points above what was measured; the range from low to high includes it.
By their numbers in this assay, from the lowest: compounds 4, 2, 3 and 1 (each within the scatter of the next, the first and the last beyond it).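

In this assay, putting 2-(trifluoromethyl)phenyl in place of 4-fluorophenyl on the aromatic nitrogen gives a number 6.7 percentage points lower from compound 2 to compound 4 (within the scatter) and so shows no clear change on its own. The new information comes from the pair that carries the same trifluoromethyl group on the phenyl ring under two different names, 4-(trifluoromethyl)phenyl and 2-(trifluoromethyl)phenyl: a number 10.5 percentage points lower from compound 3 to compound 4 (beyond the scatter) is a modest step, so at this nitrogen the number can shift with where that group sits, not only with which group is present. The step of a number 20 percentage points lower from compound 1 to compound 4 (beyond the scatter) is also modest and is the largest seen so far at this position.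

Nothing available explains these differences. The compounds shown also leave open what an amine or a carboxylic acid on this phenyl ring would do to the number.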